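Methoxy for trifluoromethyl in a cytotoxicity series at the limit

The source may report more compounds than this note shows. Statements on the series, on what has been measured and on what is new or still open speak of the compounds shown alone.

Compound 1 is `C/C(=C\c1cc(-c2ccccc2)cs1)C(N)=O`; in a functional assay on A549 cells (Homo sapiens) for cytotoxicity, read by CCK-8 assay, with a stated time of 24 h (on this read-out higher numbers stand for weaker inhibition and lower numbers for stronger inhibition), compound 1 gives > 50000 nM, which is a limit of the assay rather than a number. Compound 2 is `C/C(=C\c1cc(-c2ccc(F)cc2)cs1)C(N)=O`; in this assay compound 2 gives > 50000 nM, again a limit. Compound 3 is `C/C(=C\c1cc(-c2ccc(C(F)(F)F)cc2)cs1)C(N)=O`; in this assay compound 3 gives > 50000 nM, also a limit.

All three measured compounds share one core and differ only in the group on the six-membered aromatic ring of carbon only. Compound 3 therefore stands at the limit, not at a readable number. The three steps between them, a step that the two limits leave unreadable from compound 1 to compound 2, a step that the two limits leave unreadable from compound 1 to compound 3 and a step that the two limits leave unreadable from compound 2 to compound 3, cannot be sized because the limit of > 50000 nM in this assay, at which 3 of the 3 values shown sit, is where every value sits.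

Compound 4 is `COc1ccc(-c2csc(/C=C(\C)C(N)=O)c2)cc1`. It differs from compound 3 by methoxy in place of trifluoromethyl on an aromatic carbon. Going by the values given here, the only steps that bear on this change are the three unreadable ones, so no direction or size can be drawn from them; nothing in the measurements separates any of these substituents. The expected outcome for compound 4 is that it, too, reaches only the limit in this assay. Compound 4 is therefore estimated at 50000 nM, with a range from 20000 nM to 50000 nM. The step this estimate implies, a number no higher from compound 3 to compound 4 (the limit leaves the size open), is an expectation and not a measured change.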

Compound 4, half-maximal inhibitory concentration: > 50000 nM
Compound 4: a limit, no number (the forecaster's own chance of this, stated with the estimate: 85%); the middle value sits exactly at the limit.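

In this assay compound 4 gives > 50000 nM which is a limit of the assay and not a number. Going by these compounds alone, no step among compound 1, compound 2, compound 3 and compound 4 can be read, because all four stop at the same limit: the limit of > 50000 nM in this assay, at which 4 of the 4 values shown sit.

Still open, as far as these compounds go, is how far apart these four compounds truly lie, and whether any group on this aromatic ring gives a readable number.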